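The source may hold more compounds than are shown below. What is called first, only, known or untested is meant among the compounds shown, and "the series" means these compounds.

Measured compounds:
- compound 1 `Cn1ncc2c(=O)n(-c3ccccc3)c(SC(C)(C)c3ccccc3)nc21` — an assay on isolated protein for inhibition of Retinaldehyde dehydrogenase 3 (Homo sapiens); on this read-out higher numbers stand for weaker inhibition and lower numbers for stronger inhibition: 1390 nM
- compound 2 `C#Cc1ccc(-n2c(SC(C)c3ccccc3)nc3c(cnn3C)c2=O)cc1` — this assay: 520 nM
- compound 3 `CC(Sc1nc2c(cnn2C)c(=O)n1-c1ccccc1)c1cccc(F)c1` — this assay: 128 nM

Compound 3 gives the lowest number of the three in this assay; compound 2 sits nearest, and compound 1 furthest, with both gaps beyond the scatter. Among the measured compounds shown here, the only single-place step recorded is an 11-fold lower number from compound 1 to compound 3 (1.04 log units; beyond the scatter), which exchanges the whole sulfur substituent and so does not isolate the fluoro.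

Compound 4 `CC(Sc1nc2c(cnn2C)c(=O)n1-c1ccccc1)c1ccccc1` follows from compound 3 by hydrogen in place of fluoro on an aromatic carbon, meta to a large group. For the measured compounds named here, no measured step removes a fluoro alone. Compound 2 carries the unsubstituted 1-phenylethyl on sulfur but differs at the other aryl as well, so its value against compound 3 only hints that the unsubstituted ring may give a higher number. The expected step is a 2.0-fold higher number from compound 3 to compound 4 (0.29 log units; within the scatter), a modest rise that may stay within the scatter. Compound 4 is estimated at 250 nM, within 100 nM to 650 nM.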

Compound 4, half-maximal inhibitory concentration: 73 nM
Compound 4: the middle estimate sits 3.4-fold (0.53 log units) above what was measured; the measured number lies below the stated range.
By their numbers in this assay, from the lowest: compounds 4 and 3 (each within the scatter of the next); then compound 2; then compound 1.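

In this assay, a 1.8-fold lower number from compound 3 to compound 4 (0.24 log units; within the scatter) stays within the scatter, so fluoro and hydrogen on this aromatic carbon, meta to a large group, cannot be told apart. The large step seen earlier therefore no longer points to the fluoro: a 19-fold lower number from compound 1 to compound 4 (1.28 log units; beyond the scatter) involves only hydrogen in place of methyl on the saturated chain carbon, and this single change is enough for a large step. a 7.1-fold lower number from compound 2 to compound 4 (0.85 log units; beyond the scatter) also isolates the removal of the ethynyl, a modest step beyond the scatter.

Nothing on hand gives a reason for any of these steps. Open, going by these compounds, is whether a methoxy or an amine in place of the fluoro would move the number beyond the scatter, and whether an ethyl on the saturated chain carbon would follow the methyl.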